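The source may report more compounds than this note shows. Statements on the series, on what has been measured and on what is new or still open speak of the compounds shown alone.

Measured compounds in a functional assay on HEK293 cells for activation of melanin-concentrating hormone receptor 1 (Homo sapiens), read by inositol phosphate accumulation; on this read-out lower numbers stand for an effect already at smaller amounts and higher numbers for an effect only at larger amounts of compound:
compound 1 `CCCc1cc(N)c2cc(NC(=O)/C=C/c3ccccc3Cl)ccc2n1` gives 500 nM
compound 2 `CCCc1cc(N)c2cc(NC(=O)/C=C/c3ccc(SC)cc3)ccc2n1` gives 71 nM

Of these two numbers, compound 2 has the lower one, and the step of a 7.0-fold lower number from compound 1 to compound 2 (0.85 log units; beyond the scatter) lies beyond the scatter. Compound 3 `CCCc1cc(N)c2cc(NC(=O)/C=C/c3ccc(Cl)c(Cl)c3)ccc2n1` differs from compound 2 by 3,4-dichlorophenyl in place of 4-(methylsulfanyl)phenyl on a double-bonded chain carbon bound to a double-bonded chain carbon. For the measured compounds named here, no measured step replaces a 4-(methylsulfanyl)phenyl group with a 3,4-dichlorophenyl group; the only measured step, a 7.0-fold lower number from compound 1 to compound 2 (0.85 log units; beyond the scatter), shows that changing the ring on this chain carbon can shift this assay modestly. A small to modest rise is therefore expected, a 2.1-fold higher number from compound 2 to compound 3 (0.32 log units; beyond the scatter), with wide uncertainty. Compound 3 is estimated at 150 nM in this assay, within 40 nM to 600 nM.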

Compound 3, half-maximal effective concentration: 990 nM
Compound 3: middle estimate off by 6.6-fold (0.82 log units), on the low side; measured number above the stated range.
By their numbers in this assay, from the lowest: compound 2; then compounds 1 and 3 (each within the scatter of the next).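

In this assay, the two groups have the same number of heavy atoms, yet the change gives a 14-fold higher number from compound 2 to compound 3 (1.14 log units; beyond the scatter), so this chain carbon responds to more than group size. The two chlorine-bearing rings cannot be told apart, as a 2.0-fold higher number from compound 1 to compound 3 (0.30 log units; within the scatter) lies within the scatter, which leaves 4-(methylsulfanyl)phenyl alone with the lowest number here. No supporting data explain this difference. On these data alone, whether the sulfur matters remains open, and so does whether a 4-methoxyphenyl or 4-chlorophenyl group on this carbon would match compound 2.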